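Two Fluorines on the Phenyl of Compound 2

The source may hold more compounds than are shown below. What is called first, only, known or untested is meant among the compounds shown, and "the series" means these compounds.

In an ADME assay on MDBK cells (Bos taurus) for cytotoxicity, read by MTT assay, with a stated time of 96 h (a lower number here means that less compound is tolerated, a higher number that more compound is tolerated), compound 2 `c1ccc(/N=N/c2ccc(NC[C@@H]3CCCN4CCCC[C@H]34)c3c2CCCC3)cc1` gives > 100000 nM, which is a limit of the assay and not a number. Compound 3 `Fc1ccc(/N=N/c2ccc(NC[C@@H]3CCCN4CCCC[C@H]34)c3c2CCCC3)c(F)c1` carries 2,4-difluorophenyl in place of phenyl on a double-bonded nitrogen. The closest comparison is compound 1 `Fc1ccc(F)c(/N=N/c2ccc(NC[C@@H]3CCCN4CCCC[C@H]34)c3c2CCCC3)c1`, which carries 2,5-difluorophenyl and gives 64000 nM. Within the data shown here, the one measured step, an at least 1.5-fold higher number from compound 1 to compound 2 (0.19 log units; that floor lies within the scatter), has a floor within the scatter, so its true size remains open. Reversing that change suggests a small move to a lower number in this assay, and the expected step, an at least 1.4-fold lower number from compound 2 to compound 3 (0.15 log units; that floor lies within the scatter), stays within the scatter. Compound 3 is estimated at 70000 nM, with an expected range of 35000 nM to 130000 nM.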

Compound 3, half-maximal cytotoxic concentration: 11000 nM
For compound 3 the middle estimate is 6.4-fold (0.80 log units) above the measured one; the measured number lies below the stated range.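

In this assay, two fluorines on the phenyl are not a neutral change, and the 2,4-difluorophenyl group gives an at least 9.0-fold lower number from compound 2 to compound 3 (0.95 log units; beyond the scatter). Where the fluorines sit also counts, since 2,4-difluorophenyl in place of 2,5-difluorophenyl gives a 5.8-fold lower number from compound 1 to compound 3 (0.76 log units; beyond the scatter). Compound 2 gives > 100000 nM, which is a limit of the assay and not a number: the limit of > 100000 nM in this assay, at which 1 of the 3 values shown sits.

On these data alone, whether a single fluorine would move the number this far remains open. So does what a chlorine or a methoxy group would do at this place on the shared core.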